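A few compounds are considered here, and "the series" means these few. Any claim that something is new, unique, unknown or untested is made for them only; others in the source may bear on it.

Measured so far:
compound 1 `ClCc1cccc(Cn2cnc3ncnc(Cl)c32)c1` — 2880 nM
compound 2 `ClCc1ccc(Cn2cnc3nc(Cl)nc(Cl)c32)cc1` — > 100000 nM
compound 3 `ClCc1cccc(Cn2cnc3nc(Cl)nc(Cl)c32)c1` — > 100000 nM

In a functional assay on T47D cells (Homo sapiens) for cytotoxicity, read by sulforhodamine B assay, with a stated time of 48 h (on this read-out lower numbers stand for higher toxicity in this test and higher numbers for lower toxicity in this test), compound 1 gives 2880 nM. For compound 2 the result is a limit of the assay, > 100000 nM. For compound 3 the result is likewise a limit, > 100000 nM. The change hydrogen in place of chloro on an aromatic carbon produces an at least 34-fold lower number from compound 3 to compound 1 (1.54 log units; beyond the scatter), a step that starts from the limit of > 100000 nM in this assay, at which 2 of the 3 values shown sit. Compound 2 and compound 3 hold the same atoms joined differently; the difference between the two cores is not broken down here. Compound 4 `ClCc1ccc(Cn2cnc3ncnc(Cl)c32)cc1` is still to be measured in this assay and arises from compound 2 by hydrogen in place of chloro on an aromatic carbon, the same change as that from compound 3 to compound 1. Resting on an at least 34-fold lower number from compound 3 to compound 1 (1.54 log units; beyond the scatter), a step of an at least 20-fold lower number from compound 2 to compound 4 (1.30 log units; beyond the scatter) is expected. Compound 4 is therefore estimated at about 5000 nM, between 1500 nM and 30000 nM.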

Compound 4, concentration lethal to 50% of the cells: 6300 nM
Beside the measured number, compound 4's estimate is 1.3-fold (0.10 log units) below it, and the stated range covers the measured number.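

In this assay, hydrogen in place of chloro on the aromatic carbon between two ring nitrogen atoms gives an at least 15-fold lower number from compound 2 to compound 4 (1.20 log units; beyond the scatter), so the change carries over to the second core in the same direction and is large on both: the same change on two cores in this assay, an at least 34-fold lower number (1.54 log units; beyond the scatter) from compound 3 to compound 1 and an at least 15-fold lower number (1.20 log units; beyond the scatter) from compound 2 to compound 4; the limit leaves it open whether they differ

Both steps start from a limit of the assay, and their true sizes stay unknown: the limit of > 100000 nM in this assay, at which 2 of the 4 values shown sit.

The two pairs show the direction of the change on these two cores only, and they give no exact size on either core and say nothing about other cores.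

Still open, going by these compounds, is what an amine or a longer chain would give on that aromatic carbon in place of hydrogen. Also open, on these data alone, is what replacing the remaining chloro group on that ring with a methoxy group would give.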